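The source may hold more compounds than are shown below. What is called first, only, known or untested is meant among the compounds shown, and "the series" means these compounds.

Compound 1 `Nc1nc(N)c2ncn([C@H]3CCCC[C@H]3CO)c2n1` and compound 2 `Nc1nc(Cl)c2ncn([C@H]3CCCC[C@H]3CO)c2n1` share one core; compound 3 `CC1(C)C(CO)CC1Cn1cnc2c(N)nc(N)nc21` and compound 4 `CC1(C)C(CO)CC1Cn1cnc2c(Cl)nc(N)nc21` share another, and the difference between the two cores is not broken down here. In an ADME assay on L1210/0 cells (Mus musculus) for cytotoxicity, with a stated time of 48 h (a higher number here means a weaker inhibitor, a lower number a stronger inhibitor), compound 1 gives > 200000 nM, which is a limit of the assay and not a number. In this assay compound 2 gives > 200000 nM, likewise a limit. In this assay compound 3 gives > 200000 nM, again a limit. The change from compound 1 to compound 2 is chloro in place of amino on an aromatic carbon, and the step that the two limits leave unreadable from compound 1 to compound 2 cannot be read, since both ends are limits. The same change is made from compound 3 to compound 4: chloro in place of amino on an aromatic carbon, at a place described in the same words as before. Going by the values given here, because all three values shown sit at the limit of > 200000 nM in this assay, at which 3 of the 3 values shown sit, no measured step gives the size of this change in either core. Compound 4 is therefore expected to show a step that the limit leaves unreadable from compound 3 to compound 4, most likely again reported as a limit rather than a number. The estimate for compound 4 in this assay is 300000 nM, between 150000 nM and 2000000 nM.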

Compound 4, half-maximal inhibitory concentration: > 200000 nM
Compound 4: a limit, no number; the forecaster's own chance of this, stated with the estimate: 85%; the middle value is on the limit's open side.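

In this assay compound 4 gives > 200000 nM, a limit of the assay and not a number. No new step can be read from compound 3 to compound 4, and the four compounds shown share one reading: the limit of > 200000 nM in this assay, at which 4 of the 4 values shown sit.

As far as these compounds go, the size of any effect of chloro in place of amino on an aromatic carbon stays open in both cores.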